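Replacing 2,6-dimethylphenyl with 2-chlorophenyl in compound 4

The compounds below may be only part of what the source reports. "The series", "measured", "known", "first", "only" and "open" are said of these compounds alone.

Compound 1 `CCNc1cc(-c2ccc(NC(=O)Nc3ccc(OC)cc3)cc2C(F)(F)F)ccn1`: 5740 nM
Compound 2 `CCNc1cc(-c2ccc(NC(=O)Nc3ccc(C(F)(F)F)cc3)cc2C(F)(F)F)ccn1`: 2390 nM
Compound 3 `CCNc1cc(-c2ccc(NC(=O)Nc3c(C)cccc3C)cc2C(F)(F)F)ccn1`: 6950 nM

In a functional assay on MCF7 cells (Homo sapiens) for cytotoxicity, read by MTT assay, with a stated time of 24 h (a higher number here means a weaker inhibitor, a lower number a stronger inhibitor), compound 3 stands at the upper end of the three numbers, within the scatter of its nearest neighbour: a 1.2-fold higher number from compound 1 to compound 3 (0.08 log units; within the scatter). Its gap to the furthest is a 2.9-fold higher number from compound 2 to compound 3 (0.46 log units; beyond the scatter).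

Compound 4 `CCNc1cc(-c2ccc(NC(=O)Nc3ccccc3Cl)cc2C(F)(F)F)ccn1` differs from compound 3 as follows: 2-chlorophenyl in place of 2,6-dimethylphenyl on an amide-type nitrogen. In words, 2-chlorophenyl takes the place of 2,6-dimethylphenyl on an amide-type nitrogen.

Within the data shown here, no measured step makes this exchange. The nearest steps also alter this aryl group, and they stay small: besides those above, there is a 2.4-fold lower number from compound 1 to compound 2 (0.38 log units; beyond the scatter). A slightly lower number is therefore expected, with no step beyond the scatter. The expected step is a 1.5-fold lower number from compound 3 to compound 4 (0.19 log units; within the scatter). For compound 4 the estimate is 4500 nM, with an expected range of 2200 nM to 9000 nM.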

Compound 4, half-maximal inhibitory concentration: 3680 nM
Compound 4: the middle estimate sits 1.2-fold (0.09 log units) above what was measured, and the stated range covers the measured number.
By their numbers in this assay, from the lowest: compounds 2, 4, 1 and 3 (each within the scatter of the next, the first and the last beyond it).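

In this assay, the 2-chlorophenyl group on the amide-type nitrogen cannot be told apart from any of the three earlier aryl groups: there is a 1.9-fold lower number from compound 3 to compound 4 (0.28 log units; within the scatter) and a 1.5-fold higher number from compound 2 to compound 4 (0.19 log units; within the scatter) as well as a 1.6-fold lower number from compound 1 to compound 4 (0.19 log units; within the scatter) here. Compound 4 thus stays within the scatter of both compound 2 and compound 3, although those two stand apart beyond it, so this exchange adds no clear separate level at this position. Nothing measured here accounts for these small differences.

The compounds shown leave open whether an aminomethyl group or a carboxylic acid on this aryl ring would carry the number beyond the scatter of these four.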